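This account rests on a few compounds, and the source may have more. Where it says the series, first, only, none or still open, it means among the compounds named here.

Compound 1 `Oc1ccc(NC(=S)Nc2ccc3[nH]ccc3c2)cc1`: 41.5%
Compound 2 `COc1ccc(NC(=S)Nc2ccc3[nH]ccc3c2)cc1`: 67.6%
Compound 3 `CCOC(=O)c1ccc(NC(=S)Nc2ccc3[nH]ccc3c2)cc1`: 65.8%

These three compounds share one core and differ only in the group on the outer six-membered ring. In an ADME assay on isolated protein for inhibition of peroxidase (Raphanus sativus), read by fluorescence and Amplex Red, tested at 5 uM (on this read-out lower numbers stand for a stronger effect and higher numbers for a weaker effect at the one concentration tested), compound 1 gives the lowest of the three numbers, which on this read-out means the strongest effect. Compound 4 `CC(=O)Nc1ccc(NC(=S)Nc2ccc3[nH]ccc3c2)cc1` carries acetamido in place of hydroxy on an aromatic carbon. Two measured steps replace the same hydroxy and therefore bear on this change: a number 26.1 percentage points higher from compound 1 to compound 2 (beyond the scatter) and a number 24.3 percentage points higher from compound 1 to compound 3 (beyond the scatter). Both moved the number upward, toward a weaker effect, by a modest amount, while a number 1.8 percentage points lower from compound 2 to compound 3 (within the scatter) shows that the two replacements hardly differ from each other. A similar upward step is therefore expected for compound 4, a number 20.5 percentage points higher from compound 1 to compound 4 (beyond the scatter). Compound 4 is estimated at 62%, between 45% and 78%.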

Compound 4, a percentage reported as activity, at one concentration (the size of the read-out at that concentration, not a potency): 68.1%
Beside the measured number, compound 4's estimate is 6.1 percentage points below it; low and high end bracket the measured number.
By their numbers in this assay, from the lowest: compound 1; then compounds 3, 2 and 4 (each within the scatter of the next).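

Replacing the hydroxy of compound 1 with acetamido raises the number as well (a number 26.6 percentage points higher from compound 1 to compound 4 (beyond the scatter)), so three different groups on this aromatic carbon, para to a large group, now give a weaker effect than hydroxy. The acetamido of compound 4 is not separated from the ethoxycarbonyl (a number 2.3 percentage points higher from compound 3 to compound 4 (within the scatter)) or the methoxy (a number 0.5 percentage points higher from compound 2 to compound 4 (within the scatter)), so these three replacements sit at one level and only compound 1 stands apart. Nothing measured here accounts for this pattern.

From the compounds shown here alone, whether an amine or a carboxylic acid in this place would match the hydroxy of compound 1 or join the other three remains open.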